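Adding Fluorine to Compound 2

This account rests on a few compounds, and the source may have more. Where it says the series, first, only, none or still open, it means among the compounds named here.

Compound 1 `CC(C)(Oc1ccccc1)C1OCC(C/C=C\CCC(=O)O)C(c2cccnc2)O1` carries an unsubstituted phenyl ether on the shared core, and in an assay for inhibition of Thromboxane-A synthase (Homo sapiens), using microsomes (a lower number here means a stronger inhibitor, a higher number a weaker inhibitor), compound 1 gives 52 nM. Compound 2 `CC(C)(Oc1ccccc1[N+](=O)[O-])C1OCC(C/C=C\CCC(=O)O)C(c2cccnc2)O1` is the same molecule with nitro in place of hydrogen on an aromatic carbon. In this assay compound 2 reaches only a limit, < 10 nM, so no exact number is known for it. The nitro change gave an at least 5.2-fold lower number from compound 1 to compound 2 (0.71 log units; beyond the scatter), and that step can only be stated as a bound because of the limit of < 10 nM in this assay, at which 1 of the 2 values shown sits.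

Compound 3 `CC(C)(Oc1ccc(F)cc1[N+](=O)[O-])C1OCC(C/C=C\CCC(=O)O)C(c2cccnc2)O1` differs from compound 2 by fluoro in place of hydrogen on an aromatic carbon: the fluoro sits on the same ring, meta to a nitro group and para to a large group. Going by the values given here, no measured pair involves a fluoro, so the only step that bears on compound 3 is the nitro step, which tells where compound 2 stands rather than what the fluoro itself does. A single fluorine is a small addition, and the expected step that the limit leaves unreadable from compound 2 to compound 3 is therefore no change beyond the scatter. Compound 3 is expected at 7 nM, within 2 nM to 25 nM, most likely again reported only as the limit.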

Compound 3, half-maximal inhibitory concentration: 20 nM
The estimate for compound 3 lay 2.9-fold (0.46 log units) below the measured number, and the stated range covers the measured number.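

Going by these compounds alone, with the 4-fluoro-2-nitrophenyl group in place of the plain phenyl, this assay shows a 2.6-fold lower number from compound 1 to compound 3 (0.41 log units; beyond the scatter), which gives the advantage of a substituted ring over the unsubstituted one as an exact size for the first time. Adding fluoro at this place, meta to a nitro group and para to a large group, therefore leaves compound 3 ahead of compound 1, even though the fluoro step itself reads as an at least 2.0-fold higher number from compound 2 to compound 3 (0.30 log units; that floor lies within the scatter). Whether fluoro truly costs anything remains unsettled, and that step cannot be sized more closely because compound 2 is known only as a limit: the limit of < 10 nM in this assay, at which 1 of the 3 values shown sits.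

The compounds shown leave open what fluoro would do on a ring that carries no nitro group, so its contribution cannot yet be separated from that of the nitro group. Also open, going by these compounds, is how a chlorine or an amine at the same place, para to a large group, would compare with fluoro, and whether a nitrile could take the place of the nitro group while keeping the number low.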